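The compounds below may be only part of what the source reports. "The series", "measured", "known", "first", "only" and "open" are said of these compounds alone.

Going by the values given here, compound 1 `Cc1cc2c(cc1Cc1ccc(C(=O)NCC3CCCCC3)o1)C(C)(C)CCC2(C)C` gives 180 nM in an assay on isolated protein for binding affinity to Gonadotropin-releasing hormone receptor (Homo sapiens) (on this read-out lower numbers stand for stronger inhibition and higher numbers for weaker inhibition), the highest of the three numbers so far measured. Compound 2 `Cc1ccc(CNC(=O)c2ccc(Cc3cc4c(cc3C)C(C)(C)CCC4(C)C)o2)cc1` gives 83 nM in this assay, and compound 3 `Cc1cc2c(cc1Cc1ccc(C(=O)NCC3CCC(CN)CC3)o1)C(C)(C)CCC2(C)C` gives 42 nM. Compound 4 `Cc1cc2c(cc1Cc1ccc(C(=O)NCC3CCCC(CN)C3)o1)C(C)(C)CCC2(C)C` differs from compound 1 by aminomethyl in place of hydrogen on a saturated ring carbon. The step that bears most directly on it is a 4.3-fold lower number from compound 1 to compound 3 (0.63 log units; beyond the scatter), where an aminomethyl also enters on a saturated ring carbon; alongside this, a 2.2-fold lower number from compound 1 to compound 2 (0.34 log units; beyond the scatter) and a 2.0-fold lower number from compound 2 to compound 3 (0.30 log units; within the scatter) show that changes at the amide substituent have moved the number only modestly. Among the compounds with values here, compound 4 is therefore expected to show a lower number than compound 1, a step of about a 3.0-fold lower number from compound 1 to compound 4 (0.48 log units; beyond the scatter), kept somewhat smaller than the one seen for compound 3. Compound 4 is estimated at 60 nM, with a range from 25 nM to 150 nM.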

Compound 4, inhibition constant: 174 nM
The estimate for compound 4 lay 2.9-fold (0.46 log units) below the measured number, and the stated range ends below it.
By their numbers in this assay, from the lowest: compounds 3 and 2 (each within the scatter of the next); then compounds 4 and 1 (each within the scatter of the next).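

The aminomethyl group alone does not bring the gain seen in compound 3: as 3-(aminomethyl)cyclohexyl, it gives (a 1.0-fold lower number from compound 1 to compound 4 (0.01 log units; within the scatter)), a step within the scatter. Its placement on the ring therefore counts here, since the 3-(aminomethyl)cyclohexyl amide gives (a 4.1-fold higher number from compound 3 to compound 4 (0.62 log units; beyond the scatter)) against the 4-(aminomethyl)cyclohexyl amide, and (a 2.1-fold higher number from compound 2 to compound 4 (0.32 log units; beyond the scatter)) against the 4-methylphenyl amide. Nothing available explains this difference between the two placements. The compounds shown leave open whether an aminoethyl chain or a hydroxymethyl group at either ring place would follow the same pattern.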